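Swapping the 2,4-dichlorobenzyl group for 4-(dimethylamino)benzyl

The source may report more compounds than this note shows. Statements on the series, on what has been measured and on what is new or still open speak of the compounds shown alone.

In a functional assay on HEY cells (Homo sapiens) for cytotoxicity, read by MTT assay, with a stated time of 72 h (on this read-out lower numbers stand for stronger inhibition and higher numbers for weaker inhibition), the measured compounds read as follows:
compound 1 `N[C@H]1CC[C@H](Nc2c(C(=O)NCc3ccc(Oc4ccccc4)cc3)nc(Br)c3cccnc23)CC1` - 9000 nM
compound 2 `N[C@H]1CC[C@H](Nc2c(C(=O)NCc3ccc(F)cc3)nc(Br)c3cccnc23)CC1` - "not determined" (no result reported)
compound 3 `N[C@H]1CC[C@H](Nc2c(C(=O)NCc3ccc(Cl)cc3Cl)nc(Br)c3cccnc23)CC1` - 5000 nM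

Compound 3 (5000 nM) and compound 1 (9000 nM) lie within the scatter of each other, while compound 2 has no reported number. Compound 4 `CN(C)c1ccc(CNC(=O)c2nc(Br)c3cccnc3c2N[C@H]2CC[C@H](N)CC2)cc1` has yet to be measured. It carries 4-(dimethylamino)phenyl in place of 2,4-dichlorophenyl on a saturated chain carbon bound to an amide-type nitrogen. Within the data shown here, no measured step between compounds differing in one place is available. With only the closeness of compound 3 (5000 nM) and compound 1 (9000 nM) to go on, no shift beyond the scatter is expected in this assay in either direction. The expected change is a 1.4-fold higher number from compound 3 to compound 4 (0.15 log units; within the scatter), a small one. The estimate for compound 4 is 7000 nM, with an expected range from 3000 nM to 16000 nM.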

Compound 4, half-maximal inhibitory concentration: 5300 nM
Compound 4: middle estimate off by 1.3-fold (0.12 log units), on the high side, and the stated range covers the measured number.
By their numbers in this assay, from the lowest: compounds 3, 4 and 1 (each within the scatter of the next).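

In this assay, 4-(dimethylamino)phenyl can stand in place of 2,4-dichlorophenyl on a saturated chain carbon bound to an amide-type nitrogen without leaving the scatter (a 1.1-fold higher number from compound 3 to compound 4 (0.03 log units; within the scatter)). Dimethylamino in place of phenoxy on an aromatic carbon likewise stays within the scatter (a 1.7-fold lower number from compound 1 to compound 4 (0.23 log units; within the scatter)). No evidence is available on why these groups read alike.

Going by these compounds, whether a carboxylic acid or a primary amine on this aromatic ring would move the number beyond the scatter remains open. Compound 2 offers no number for comparison.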